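The source may hold more compounds than are shown below. What is called first, only, known or untested is meant among the compounds shown, and "the series" means these compounds.

Measured so far:

Compound 1, `CCCCC(NC(=O)C(CC(C)C)NC(=O)OCc1ccccc1)C(=O)C(=O)OCC`, gives 180 nM in an assay on isolated protein (Oryctolagus cuniculus) for inhibition of Calpain-2 catalytic subunit (Homo sapiens), at pH 8.0; on this read-out lower numbers stand for stronger inhibition and higher numbers for weaker inhibition.
Compound 2, `CCCCNC(=O)C(=O)C(CC)NC(=O)C(CC(C)C)NC(=O)OCc1ccccc1`, gives 50 nM in this assay.

Of the two numbers, compound 2 has the lower one, and the gap between compound 2 and compound 1 lies beyond the usual scatter of repeated measurements, so compound 2 stands as the stronger of the two measured inhibitors. Compound 3, `CCC(NC(=O)C(CC(C)C)NC(=O)OCc1ccccc1)C(=O)C(=O)NCc1ccccc1`, has not yet been measured. It keeps the whole of compound 2 apart from one change: phenyl in place of propyl on a saturated chain carbon bound to an amide-type nitrogen. Within the data shown here, no pair of measured compounds shows this same change, so nothing in the numbers so far tells how large a step it brings; the expectation rests on compound 2 alone and on the change as counted. A small step is expected, if any, towards lower numbers, and it may well stay within the scatter. The step expected from compound 2 to compound 3 is a 1.4-fold lower number from compound 2 to compound 3 (0.15 log units; within the scatter). For compound 3 the expected inhibition constant in this assay is 35 nM, with a range from 12 nM to 110 nM.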

Compound 3, inhibition constant: 22 nM
The estimate for compound 3 lay 1.6-fold (0.20 log units) above the measured number, within the range that was stated.
By their numbers in this assay, from the lowest: compound 3; then compound 2; then compound 1.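

Swapping phenyl in for propyl on a saturated chain carbon bound to an amide-type nitrogen, which turns butylcarbamoyl into benzylcarbamoyl, gives a 2.3-fold lower number from compound 2 to compound 3 (0.36 log units; beyond the scatter) in this assay. Among these compounds, until now no measured pair spoke to this position, and this pair shows that the group carried on that amide nitrogen can move the inhibition constant by more than repeat measurements would, and that a six-membered aromatic ring of carbon only is accepted there, at least in this one pair. No separate measurement bears on why the number falls with this change.

This single pair cannot separate the effect of having a ring from that of having more carbon atoms, so cyclohexylmethyl, which keeps a ring but not an aromatic one, or a longer chain such as phenethyl or a butyl chain ending in an amine, would each be needed to tell those readings apart. On these data alone, whether the same change brings a step of similar size on any other core also stays open, since one pair sets no general pattern.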